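The source may report more compounds than this note shows. Statements on the series, on what has been measured and on what is new or still open speak of the compounds shown alone.

Measured compounds:
compound 1 `C[C@@H](NC(=O)c1ccc(C#Cc2ccccc2)cn1)C(C)(C)O`: 60.9%
compound 2 `C[C@@H](NC(=O)c1ccc(C#Cc2ccncc2)cn1)C(C)(C)O`: 66.6%

In a functional assay on HEK293 cells for positive allosteric modulation of metabotropic glutamate receptor 5 (Rattus norvegicus), read by fluorescence and calcium flux (a higher number here means a larger maximal response, a lower number a smaller maximal response), compound 1 gives 60.9%. Among the compounds with values here, compound 2, the only other measured compound, gives 66.6%, so compound 1 stands within the usual scatter of its single neighbour, and the step of a number 5.7 percentage points higher from compound 1 to compound 2 (within the scatter) is within the scatter.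

Compound 3 `C[C@@H](NC(=O)c1ccc(C#CC2CCCC2)cn1)C(C)(C)O` differs from compound 1 by cyclopentyl in place of phenyl on a triple-bonded carbon. Within the data shown here, only one measured step bears on this place, the one from compound 1 to compound 2, and there one six-membered aromatic ring replaced another on the triple-bonded carbon without moving the maximal response beyond the scatter. Among the measured compounds shown here, the change to compound 3 is different in kind: the ring that enters is non-aromatic and five-membered, and no measured pair shows what such a ring does on this carbon. The closest evidence says this position tolerates a swap of ring without a clear shift, so no step beyond the scatter is expected in this assay, with the uncertainty widened for the untested ring type. Compound 3 is estimated at 55% (range 35% to 75%), meaning an expected step of a number 5.9 percentage points lower from compound 1 to compound 3 (within the scatter).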

Compound 3, largest response reached (reported as efficacy), in percent of the reference or control that the assay uses: 63.7%
The estimate for compound 3 lay 8.7 percentage points below the measured number, and the stated range covers the measured number.
By their numbers in this assay, from the lowest: compounds 1, 3 and 2 (each within the scatter of the next).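

Within the data shown here, until now, the only change at this place was one six-membered aromatic ring for another. Compound 3 extends this to a five-membered non-aromatic ring of carbon only: in this assay, the cyclopentyl change gives a number 2.8 percentage points higher from compound 1 to compound 3 (within the scatter), and the comparison with the pyridin-4-yl compound gives a number 2.9 percentage points lower from compound 2 to compound 3 (within the scatter). Phenyl, pyridin-4-yl and cyclopentyl therefore cannot be told apart by largest response, so among these three compounds, neither the loss of the aromatic ring nor the smaller ring shows up as a step beyond the scatter. Nothing available explains why the response stays level across these rings.

The compounds shown leave open whether this tolerance reaches beyond a ring of five or six members, for example to a longer open chain, an amine or a carboxylic acid on the triple-bonded carbon. They also leave open whether these same changes would stay as quiet in a read-out other than largest response, such as the amount of compound needed to reach it.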